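Adding a Methyl on the Shared Core: Cytotoxicity Outlook

The source may report more compounds than this note shows. Statements on the series, on what has been measured and on what is new or still open speak of the compounds shown alone.

Three compounds sharing one core were tested in a toxicity assay on MT2 cells (Homo sapiens) for cytotoxicity, read by MTT assay; on this read-out lower numbers stand for higher toxicity in this test and higher numbers for lower toxicity in this test. Compound 1 `Cc1c(Oc2ccccc2OCCn2ccc(=O)[nH]c2=O)cc(F)c2ccc(C#N)cc12` gave a reading that is a limit of the test, > 100000 nM. Compound 2 `Cc1c(Oc2ccccc2OCCn2ccc(=O)[nH]c2=O)cc(Cl)c2ccc(C#N)cc12` likewise reached only a limit, > 100000 nM. Compound 3 `Cc1cc(Oc2ccccc2OCCn2ccc(=O)[nH]c2=O)c(C)c2cc(C#N)ccc12` also sits at a limit, > 100000 nM. Because (the limit of > 100000 nM in this assay, at which 3 of the 3 values shown sit), the steps between them cannot be read: a step that the two limits leave unreadable from compound 1 to compound 2, a step that the two limits leave unreadable from compound 1 to compound 3 and a step that the two limits leave unreadable from compound 2 to compound 3. So compound 3 stands where both its neighbours stand, at the limit of this test rather than at a number.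

Compound 4 `CCc1cc(Oc2ccccc2OCCn2ccc(=O)[nH]c2=O)c(C)c2cc(C#N)ccc12` differs from compound 3 by methyl in place of hydrogen on a saturated chain carbon bound to an aromatic carbon. Going by the values given here, none of the measured steps gives a readable size, so no direction can be drawn from them; the three measured compounds, differing only in the group on an aromatic carbon, all ended at the same limit in this assay. The expectation is therefore that compound 4 will again end at that limit, with no step beyond the scatter expected: a step that the limit leaves unreadable from compound 3 to compound 4. Compound 4 is estimated at 150000 nM, within 50000 nM to 500000 nM, and most likely reported only as a limit.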

Compound 4, half-maximal cytotoxic concentration: 12000 nM
Beside the measured number, compound 4's estimate is 13-fold (1.10 log units) above it; measured number below the stated range.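

Going from methyl to ethyl, with methyl in place of hydrogen on a saturated chain carbon bound to an aromatic carbon, gave the only reading in this assay among these compounds that is a number and not a limit, and the change runs toward higher toxicity in this test: an at least 8.3-fold lower number from compound 3 to compound 4 (0.92 log units; beyond the scatter) is the step. The changes on an aromatic carbon had left every reading unreadable, whereas the comparisons with compound 4 also clear the scatter, with an at least 8.3-fold lower number from compound 2 to compound 4 (0.92 log units; beyond the scatter) for ethyl in place of chloro and an at least 8.3-fold lower number from compound 1 to compound 4 (0.92 log units; beyond the scatter) for ethyl in place of fluoro, so this read-out does respond to the shared core once the group at this place changes. All three sizes are floors and not measured gaps, since each starts from a limit: the limit of > 100000 nM in this assay, at which 3 of the 4 values shown sit.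

Going by these compounds, the true size of the step stays open, as does whether it would continue with a longer chain such as propyl. On these data alone, whether a branched isopropyl group or an amine on that same carbon would move the reading the same way also remains unknown.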